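The source may report more compounds than this note shows. Statements on the series, on what has been measured and on what is new or still open speak of the compounds shown alone.

For the measured compounds named here, in a functional assay, read by spectrophotometry, with a stated time of 30 min (on this read-out higher numbers stand for weaker inhibition and lower numbers for stronger inhibition), compound 2 `CCc1ccccc1NNC(=O)CC[C@H](N)C(=O)O` gives 17.1 ug/mL, the higher of the two numbers so far; compound 1 `Cc1ccccc1NNC(=O)CC[C@H](N)C(=O)O` gives 6.24 ug/mL. Going by the values given here, the single measured step, a 2.7-fold higher number from compound 1 to compound 2 (0.44 log units; beyond the scatter), is the only one that bears on compound 3 `N[C@@H](CCC(=O)NNc1ccccc1F)C(=O)O`, which differs from compound 2 by fluoro in place of ethyl on an aromatic carbon. That step added a methyl on the saturated chain carbon; the change to compound 3 takes the ethyl away altogether and enters one fluorine, so a move back toward the number of compound 1 is expected. The expected step is a 2.4-fold lower number from compound 2 to compound 3 (0.39 log units; beyond the scatter). Compound 3 is therefore estimated at 7 ug/mL, with a range from 3 ug/mL to 20 ug/mL.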

Compound 3, half-maximal inhibitory concentration: 10.9 ug/mL
Compound 3: middle estimate off by 1.6-fold (0.19 log units), on the low side; low and high end bracket the measured number.
By their numbers in this assay, from the lowest: compounds 1, 3 and 2 (each within the scatter of the next, the first and the last beyond it).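

In this assay, fluoro in place of ethyl on the aromatic carbon gives a 1.6-fold lower number from compound 2 to compound 3 (0.20 log units; within the scatter) and fluoro in place of methyl gives a 1.7-fold higher number from compound 1 to compound 3 (0.24 log units; within the scatter) at the same place. Compound 3 thus cannot be told apart from either neighbour at this position, ortho to a large group, although compound 1 and compound 2 stand apart beyond the scatter. No measurement at hand accounts for these readings. Open, from the compounds shown here alone, is whether an amine, a methoxy group or chlorine on this aromatic carbon would read differently, and whether a longer chain there would extend the step from methyl to ethyl.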